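From ethynyl to thiophene on a weak growth inhibitor

The compounds below may be only part of what the source reports. "The series", "measured", "known", "first", "only" and "open" are said of these compounds alone.

Of the compounds shown here, two have so far been tested in a functional assay on SNB-19 cells (Homo sapiens) for inhibition, read by MTT assay, with a stated time of 7 days; a higher number here means a weaker inhibitor of growth, a lower number a stronger inhibitor of growth. Compound 1 (`Cc1cc(Cn2nnc3c(C(N)=O)ncn3c2=O)on1`) gives only a limit of the assay (> 50000 nM). Going by the values given here, compound 2 (`C#CC/N=N/Nc1[nH]cnc1C(N)=O`) gives the only actual number (39100 nM), which makes it the sole numerical starting point here, and that number marks a weak inhibitor.

Compound 3 (`NC(=O)c1nc[nH]c1N/N=N/Cc1ccsc1`) keeps the core of compound 2 but has thiophen-3-yl in place of ethynyl on a saturated chain carbon bound to a double-bonded nitrogen. Among the compounds with values here, no measured pair in this set shows what a single change of this kind does in this assay. The expectation is therefore cautious: a slight gain in potency, but none beyond the scatter. The estimated step is small (a 1.3-fold lower number from compound 2 to compound 3 (0.12 log units; within the scatter)). For compound 3 the expected value is 30000 nM (estimated range 12000 nM to 50000 nM).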

Compound 3, concentration for 50% growth inhibition: > 50000 nM
Compound 3 gave a limit, no number; the forecaster's own chance of this, stated with the estimate: 30%; middle value at least 1.6-fold (0.22 log units) away from the limit.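

Compound 3 gives only a limit of the assay (> 50000 nM), not a number. Going by these compounds alone, putting thiophen-3-yl in place of ethynyl on a saturated chain carbon bound to a double-bonded nitrogen gives the only step readable at this position in this assay (an at least 1.2-fold higher number from compound 2 to compound 3 (0.10 log units; that floor lies within the scatter)), so this aromatic ring brings no gain in potency over ethynyl, which the earlier compounds could not show. How large the loss is, or whether there is any real loss at all, cannot be told, because the true value of compound 3 lies out of reach of the assay: the limit of > 50000 nM in this assay, at which 2 of the 3 values shown sit.

From the compounds shown here alone, what remains open is whether any group at this position can lower the number. A phenyl ring, an amine or a longer chain in place of ethynyl would each be a further test of that.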